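The source may hold more compounds than are shown below. What is called first, only, known or untested is meant among the compounds shown, and "the series" means these compounds.

Measured so far:
- compound 1, `COC(=O)Nc1cc(-c2ccc(OC[C@@](C)(N)CC(C)C)c(C)c2)ccn1`: 75%
- compound 2, `COC(=O)Nc1cc(-c2cc(Cl)c(OC[C@@](C)(N)CC(C)C)cn2)ccn1`: 87%
- compound 3, `CC(=O)Nc1cc(-c2cc(F)c(OC[C@@H](N)CC(C)C)c(F)c2)ccn1`: 90%

In an ADME assay on microsomes from liver (Mus musculus) for metabolic stability, read by LC-MS, using NADPH, with a stated time of 10 min, tested at 0.5 uM (a higher number here means that more of the compound is left, a lower number that less of the compound is left), compound 1 gives 75%, the lowest of the three values shown. Compound 2 gives 87% in this assay, a gap to compound 1 beyond the usual scatter, and compound 3 gives 90%, again beyond the scatter from compound 1. Within the data shown here, no single-point step between measured compounds is available, so none of these gaps can be tied to one structural change.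

Compound 4, `COC(=O)Nc1cc(-c2ccc(OC[C@@](C)(N)CC(C)C)c(C)c2C)ccn1`, is not yet measured. It differs from compound 1 as follows: methyl in place of hydrogen on an aromatic carbon. Among the measured compounds shown here, the change adds one carbon on the shared core, and nothing among the measured compounds isolates such a change. The expectation is therefore for no step beyond the scatter in this assay, with the estimated step from compound 1 to compound 4 being a number 1 percentage points lower from compound 1 to compound 4 (within the scatter). In this assay compound 4 is expected to give 74%, with a range from 55% to 90%.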

Compound 4, percent of the compound remaining: 70%
Estimate against measurement, compound 4: 4 percentage points above; the range from low to high includes it.
By their numbers in this assay, from the lowest: compounds 4 and 1 (each within the scatter of the next); then compounds 2 and 3 (each within the scatter of the next).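

In this assay, among these compounds, methyl in place of hydrogen on an aromatic carbon, ortho to a large group and ortho to a methyl group, gives a number 5 percentage points lower from compound 1 to compound 4 (within the scatter), the first step that can be tied to a single place. Among the compounds shown here, this position therefore takes a methyl without a shift beyond the scatter in the amount of compound left, which the earlier compounds could not show. Nothing at hand explains this result.

Open, going by these compounds, is whether a different group at this position, such as an ethyl, a methoxy or an amine, would also stay within the scatter. Also open, on these data alone, is whether the same methyl would give a similar step on the structures of compound 2 and compound 3.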